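Working notes: methoxy to cyano on the shared core

The compounds below may be only part of what the source reports. "The series", "measured", "known", "first", "only" and "open" are said of these compounds alone.

Three compounds on the shared core have numbers in a functional assay on the whole organism for inhibition, with Rattus norvegicus as the target, at a dose of 30 mg/kg; on this read-out higher numbers stand for more inhibition at the one dose given (going by the name of the read-out) and lower numbers for less inhibition. Compound 1 `CSc1ccccc1-c1nc2ncccc2o1` gives 21%. Compound 2 `Clc1ccccc1-c1nc2ncccc2o1` gives 38%. Compound 3 `COc1ccccc1-c1nc2ncccc2o1` gives 9%, the lowest of the three numbers; its nearest neighbour is compound 1 and the furthest is compound 2, both beyond the scatter. The single-point changes among these three are all modest: chloro in place of methylsulfanyl on an aromatic carbon gave a number 17 percentage points higher from compound 1 to compound 2 (beyond the scatter), methoxy in place of methylsulfanyl gave a number 12 percentage points lower from compound 1 to compound 3 (beyond the scatter), and methoxy in place of chloro gave a number 29 percentage points lower from compound 2 to compound 3 (beyond the scatter).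

Compound 4 `N#Cc1ccccc1-c1nc2ncccc2o1` has no number yet. It differs from compound 3 in one place: cyano in place of methoxy on an aromatic carbon. Among the measured compounds shown here, no measured step introduces cyano, so nothing bears on it directly. The two steps that do bear on the position, a number 12 percentage points lower from compound 1 to compound 3 (beyond the scatter) and a number 29 percentage points lower from compound 2 to compound 3 (beyond the scatter), both end at methoxy and both run downward, so leaving methoxy is expected to move the number back upward by a modest step, though the size is uncertain. Compound 4 is therefore estimated at 24%, within a range from 5% to 45%. This estimate corresponds to an expected step of a number 15 percentage points higher from compound 3 to compound 4 (beyond the scatter).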

Compound 4, a percentage reported as inhibition, in the whole organism at one dose (the size of the read-out at that dose, not a potency): 62%
Compound 4: middle estimate off by 38 percentage points, on the low side; the measured number lies above the stated range.
By their numbers in this assay, from the lowest: compound 3; then compound 1; then compound 2; then compound 4.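

In this assay, among the compounds shown here, this position proves able to carry far more than the modest steps among the earlier compounds showed, and chloro no longer marks the top of the set: cyano in place of methoxy gives a number 53 percentage points higher from compound 3 to compound 4 (beyond the scatter) and cyano in place of methylsulfanyl gives a number 41 percentage points higher from compound 1 to compound 4 (beyond the scatter) while cyano in place of chloro still gives a number 24 percentage points higher from compound 2 to compound 4 (beyond the scatter) and so compound 4 stands above all three others. The large step from methoxy to cyano comes with no change in the counts of heavy atoms, hydrogen-bond donors or hydrogen-bond acceptors, so those counts do not separate the two groups, although a triple bond enters with cyano. Nothing shown here accounts for the size of this rise.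

Four groups at one position on one core, each read at a single dose, leave the shape of the dose response open, and with it how far these numbers reflect potency. Also open, going by these compounds, is how an amine, a carboxylic acid or a longer chain ending in cyano would read in the same place, and whether cyano would keep its lead elsewhere on the six-membered aromatic ring.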